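Changing the Aromatic Group on the Ring Nitrogen

The compounds below may be only part of what the source reports. "The series", "measured", "known", "first", "only" and "open" are said of these compounds alone.

Two compounds have been measured in a functional assay on HCT-116 cells (Homo sapiens) for antiproliferative activity, read by MTT assay, with a stated time of 48 h; on this read-out higher numbers stand for weaker inhibition and lower numbers for stronger inhibition:

Compound 1 `N#CC1=C(N)Oc2c(c3nc4ccccc4nc3c3ccccc23)C12C(=O)N(Cc1cnnn1-c1ccc(S(N)(=O)=O)cc1)c1ccccc12`: 31200 nM
Compound 2 `CCOc1ccccc1-n1nncc1CN1C(=O)C2(C(C#N)=C(N)Oc3c(N)cc4nc5ccccc5nc4c32)c2ccccc21`: > 50000 nM

Compound 1 gives a weak but measurable inhibition of cell growth. Compound 2, by contrast, reaches only the limit of this assay, so no number is known for it beyond the statement (the limit of > 50000 nM in this assay, at which 1 of the 2 values shown sits). Between these two compounds no single-point step exists, and so nothing shows how large a change one substituent swap produces here.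

Compound 3 `Cc1cc(C)c(-n2nncc2CN2C(=O)C3(C(C#N)=C(N)Oc4c(N)cc5nc6ccccc6nc5c43)c3ccccc32)c(C)c1` differs from compound 2 in one place: 2,4,6-trimethylphenyl in place of 2-ethoxyphenyl on an aromatic nitrogen. Both groups are aromatic rings of similar size without donors.

The expected step in this assay from compound 2 to compound 3 is a number no higher from compound 2 to compound 3 (the limit leaves the size open), that is, no shift beyond the usual scatter. Compound 3 is therefore expected to give 50000 nM, within 20000 nM to 120000 nM, quite possibly reported again only as a limit.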

Compound 3, half-maximal inhibitory concentration: > 50000 nM
Compound 3 was reported as a limit; the forecaster's own chance of this, stated with the estimate: 60%; the middle value lies on the limit itself.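

Among the compounds shown here, compound 2 and compound 3 are both reported only as limits in this assay, so the swap of 2-ethoxyphenyl for 2,4,6-trimethylphenyl gives no step that can be read. The compounds shown leave open what real numbers lie behind these limits, and so whether this swap changes growth inhibition at all.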